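This account rests on a few compounds, and the source may have more. Where it says the series, first, only, none or still open, it means among the compounds named here.

Working notes on the series. Compound 1 `CC(C(=O)NCc1ccc(C(F)(F)F)nc1)c1ccc(NS(C)(=O)=O)c(F)c1` carries no substituent on the aromatic carbon next to the ring nitrogen and in a functional assay on CHO-K1 cells for antagonist activity at transient receptor potential cation channel subfamily V member 1 (Homo sapiens), read by FLIPR (on this read-out higher numbers stand for weaker inhibition and lower numbers for stronger inhibition), compound 1 is recorded as "not active" (no number reported), so no number places it. Compound 2 `Cc1ccc(Nc2nc(C(F)(F)F)ccc2CNC(=O)C(C)c2ccc(NS(C)(=O)=O)c(F)c2)cc1C` puts 3,4-dimethylphenyl on the nitrogen at that carbon and in this assay compound 2 gives 1160 nM; compound 3 `CC(C(=O)NCc1ccc(C(F)(F)F)nc1NCc1ccccc1)c1ccc(NS(C)(=O)=O)c(F)c1` puts benzyl there and in this assay compound 3 gives 203 nM. Among the measured compounds shown here, the one measured step, a 5.7-fold lower number from compound 2 to compound 3 (0.76 log units; beyond the scatter), shows that the group on that position moves the read-out by a modest amount and that either group yields a measurable number where compound 1 yields none.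

Compound 4 `CC(C(=O)NCc1ccc(C(F)(F)F)nc1N1CCC(C(F)(F)F)CC1)c1ccc(NS(C)(=O)=O)c(F)c1` differs from compound 1 by 4-(trifluoromethyl)piperidin-1-yl in place of hydrogen on an aromatic carbon, a cyclic amine without a pendant aryl, so neither measured step maps onto it directly. The expectation is that the change confers activity, with a number in the range spanned by compound 2 and compound 3. Compound 4 is expected to give about 500 nM in this assay, estimated between 100 nM and 5000 nM.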

Compound 4, half-maximal inhibitory concentration: 31 nM
Compound 4: middle estimate off by 16-fold (1.21 log units), on the high side, and the stated range ends above it.
By their numbers in this assay, from the lowest: compound 4; then compound 3; then compound 2.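

Working at the aromatic carbon next to the ring nitrogen, a cyclic amine without a pendant aryl gives the lowest number of the series so far, with a 6.5-fold lower number from compound 3 to compound 4 (0.82 log units; beyond the scatter) and a 37-fold lower number from compound 2 to compound 4 (1.57 log units; beyond the scatter). Among the compounds shown here, compound 1 has no number, so the step to compound 4 cannot be read; the values show only that in this assay compound 4 gives 31 nM, where compound 1 is recorded as "not active" (no number reported). Nothing measured here bears on the reason for this result.

The compounds shown leave open how much of the gain belongs to the trifluoromethyl on the piperidine and how much to the ring itself. A plain piperidin-1-yl, a 4-methylpiperidin-1-yl or a morpholin-4-yl at the same carbon would separate the two.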